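The source may hold more compounds than are shown below. What is called first, only, known or untested is meant among the compounds shown, and "the series" means these compounds.

For the measured compounds named here, compound 1, with the structure `NC(=O)[C@@H]1CC[C@H](c2ccc(Oc3ccc(F)cc3)cc2)N1`, is the only compound in this set with a numeric reading. In an ADME assay on microsomes from liver (Rattus norvegicus) for metabolic stability (on this read-out higher numbers stand for fast clearance and lower numbers for slow clearance), compound 1 gives 2 mL.min-1.g-1. Compound 2, with the structure `NC(=O)[C@@H]1CC[C@H](c2ccc(OCc3cccc(F)c3)cc2)N1`, is the other compound measured, and in this assay compound 2 reaches only a limit, < 0.5 mL.min-1.g-1. Going by the values given here, that is the limit of the measurement, not a number, so no step between compound 1 and compound 2 can be sized; one of the two values shown sits at the limit of < 0.5 mL.min-1.g-1 in this assay, at which 1 of the 2 values shown sits, and compound 1 stands above that limit.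

Compound 3, with the structure `NC(=O)[C@@H]1CC[C@H](c2ccc(Oc3cccc(F)c3)cc2)N1`, has not yet been measured in this assay. It differs from compound 1 in one place: 3-fluorophenyl in place of 4-fluorophenyl on an oxygen on an aromatic ring. Among the compounds with values here, no measured pair in this set differs in exactly this way, so there is no direct step to lean on. The expectation for compound 3 is a step of about a 1.8-fold higher number from compound 1 to compound 3 (0.24 log units; within the scatter), upward, close to the edge of the usual scatter. On that basis compound 3 is estimated to give 3.5 mL.min-1.g-1 in this assay, with a plausible range from 1.5 mL.min-1.g-1 to 8 mL.min-1.g-1.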

Compound 3, intrinsic clearance in microsomes: 2 mL.min-1.g-1
The estimate for compound 3 lay 1.8-fold (0.24 log units) above the measured number, and the stated range covers the measured number.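

In this assay, for the compounds shown here, 3-fluorophenyl in place of 4-fluorophenyl on an oxygen on an aromatic ring gives no change at the digits printed from compound 1 to compound 3 (within the scatter) and this is the first step in the set that can be sized at all. For this position it shows that the two fluorophenyl groups, which have the same atoms joined differently, are not told apart by this read-out, so the place of the fluorine on this ring, as far as these two compounds go, leaves the clearance reading where it was. Nothing at hand offers a reason for this outcome.

Compound 2 gives < 0.5 mL.min-1.g-1 in this assay and that is a limit of the assay and not a number, so the steps that involve it cannot be read. On these data alone, what stays open is whether the reading would also hold with something other than fluorine on this ring, such as chlorine, an amine or a carboxylic acid, and whether the same change of fluorine place would leave the reading alone on the shared core with a longer chain in the link to the ring.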